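Swapping (butylsulfanyl)methyl for ethoxycarbonyl on the shared core

The compounds below may be only part of what the source reports. "The series", "measured", "known", "first", "only" and "open" are said of these compounds alone.

Measured in a functional assay on L1210 cells (Mus musculus) for cytotoxicity; a higher number here means a weaker inhibitor, a lower number a stronger inhibitor:
compound 1 `CC[C@H]1OC(n2cc(F)c(=O)[nH]c2=O)[C@H](O)[C@@H]1O` gives 19 uM
compound 2 `CCCCSC[C@H]1OC(n2cc(F)c(=O)[nH]c2=O)[C@H](O)[C@@H]1O` gives 270 uM

Of these two, compound 2 has the higher number, which makes it the weaker inhibitor. Among the measured compounds shown here, the single measured step is a 14-fold higher number from compound 1 to compound 2 (1.15 log units; beyond the scatter), and it lies beyond the usual scatter.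

Compound 3 `CCOC(=O)[C@H]1OC(n2cc(F)c(=O)[nH]c2=O)[C@H](O)[C@@H]1O` carries ethoxycarbonyl in place of (butylsulfanyl)methyl on a saturated ring carbon. The measured step bears on this change only loosely. It altered the same side chain, but neither measured compound carries an ester, so the data cannot show what this group does.

The butylsulfanyl part arrived with the rise to compound 2 at 270 uM, and here it leaves again. A drop in this assay is therefore expected, smaller than the measured step and going only part of the way back towards compound 1 at 19 uM. The estimated step is a 4.5-fold lower number from compound 2 to compound 3 (0.65 log units; beyond the scatter). For compound 3 the expected value is 60 uM, with an estimated range from 12 uM to 250 uM.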

Compound 3, concentration for 50% inhibition: > 1000 uM
Compound 3 gave a limit, no number; the forecaster's own chance of this, stated with the estimate: 5%; at least 16-fold (1.22 log units) between middle value and limit.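

In this assay compound 3 gives > 1000 uM, which is a limit of the assay and not a number. Taking away the butylsulfanyl part therefore did not bring the number back towards that of compound 1, as the ester instead gives an at least 3.7-fold higher number from compound 2 to compound 3 (0.56 log units; beyond the scatter), and compared directly with the ethyl group the change is an at least 52-fold higher number from compound 1 to compound 3 (1.72 log units; beyond the scatter). With only compound 2 in hand, the loss of potency could have been peculiar to a sulfur-containing chain, but compound 3 has no sulfur and no butyl chain, so on this saturated ring carbon next to the ring oxygen, both replacements shown for ethyl give a weaker inhibitor, and the ester gives the weaker of the two.

How far compound 3 really lies from the other two stays unknown, and so does the full size of both steps: the limit of > 1000 uM in this assay, at which 1 of the 3 values shown sits. The compounds shown also leave open whether the ester itself matters or any group other than ethyl would do the same, which a carboxylic acid, a primary amide, a hydroxymethyl group or a plain propyl chain on this carbon could help to separate.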